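The source may hold more compounds than are shown below. What is called first, only, known or untested is meant among the compounds shown, and "the series" means these compounds.

The series shares one core, shown in compound 1 `O=C1Nc2ccc(Br)cc2/C1=N/NC(=S)N/N=C/c1ccc(-c2ccccc2)cc1`, compound 2 `O=C1Nc2ccc(Br)cc2/C1=N/NC(=S)N/N=C/c1c(F)cccc1Cl` and compound 3 `O=C1Nc2ccc(Br)cc2/C1=N/NC(=S)N/N=C/c1c(Cl)cccc1Cl`, and differs only in the aryl group that hangs from the carbon double-bonded to nitrogen. In a functional assay on COS-7 cells (Chlorocebus aethiops) for inhibition, read by MTT assay (on this read-out higher numbers stand for weaker inhibition and lower numbers for stronger inhibition), compound 1 gives > 50000 nM, which is a limit of the assay rather than a number. Compound 2 gives 2560 nM in this assay and stands lowest of the two numbers shown. Going by the values given here, compound 3 gives 6730 nM, and the single step between measured neighbours, a 2.6-fold higher number from compound 2 to compound 3 (0.42 log units; beyond the scatter), is the only measured step on which a forecast can rest. Compound 4 `O=C1Nc2ccc(Br)cc2/C1=N/NC(=S)N/N=C/c1ccccc1Br` is not yet measured; it differs from compound 2 by 2-bromophenyl in place of 2-chloro-6-fluorophenyl on a carbon with a double bond to nitrogen. Among the compounds with values here, since the one measured step, chloro for fluoro, gave a 2.6-fold higher number from compound 2 to compound 3 (0.42 log units; beyond the scatter), and the change to compound 4 likewise replaces a halogen with a heavier one while also dropping the fluorine, a modest weakening is expected for compound 4, that is a step of a 2.0-fold higher number from compound 2 to compound 4 (0.29 log units; within the scatter) in this assay. Compound 4 is therefore estimated at 5000 nM in this assay, between 1500 nM and 20000 nM.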

Compound 4, half-maximal inhibitory concentration: > 50000 nM
Compound 4 gave a limit, no number; the forecaster's own chance of this, stated with the estimate: 8%; at least 10-fold (1.00 log units) between middle value and limit.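

In this assay, going by these compounds alone, the only measured step among numbered values had been a modest one, but 2-bromophenyl in place of 2-chloro-6-fluorophenyl on a carbon with a double bond to nitrogen gives an at least 19-fold higher number from compound 2 to compound 4 (1.29 log units; beyond the scatter), which shows that this place can tolerate far less change than that step suggested. Measured against 2,6-dichlorophenyl, the same group gives an at least 7.4-fold higher number from compound 3 to compound 4 (0.87 log units; beyond the scatter), so the presence of a halogen on the phenyl ring is not by itself enough to keep the number in the range of compound 2 and compound 3. The result for compound 4 is a limit and not a number, and compound 1 shares it: the limit of > 50000 nM in this assay, at which 2 of the 4 values shown sit.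

The change to compound 4 swaps in bromo and removes the other halogen in one step, and the compounds shown cannot tell these two parts apart. Also open, on these data alone, is how a phenyl group carrying only fluoro or only chloro, or one carrying a methoxy group or an amine, would behave on that carbon.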